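Carbamate replaced by aminobenzamide on the aryl amine

The source may report more compounds than this note shows. Statements on the series, on what has been measured and on what is new or still open speak of the compounds shown alone.

For the measured compounds named here, compound 1 `CCCCOC(=O)Nc1ccc(S(=O)(=O)N2C[C@H](c3ccccc3)NC2=O)cc1CC` gives 200 nM in a functional assay on A549 cells (Homo sapiens) for cytotoxicity, read by MTT assay (a lower number here means a stronger inhibitor, a higher number a weaker inhibitor), and holds the only number in the set. Compound 2 `CCOC(=O)Nc1c(C)cc(S(=O)(=O)N2C[C@H](c3ccccc3)NC2=O)cc1C` falls at the limit of > 10000 nM in this assay, at which 1 of the 2 values shown sits; its entry of > 10000 nM is a limit of the assay, not a number. Compound 3 `CCc1cc(S(=O)(=O)N2C[C@H](c3ccccc3)NC2=O)ccc1NC(=O)c1ccc(N)cc1` differs from compound 1 by 4-aminophenyl in place of butoxy on a carbonyl carbon. Going by the values given here, no measured pair tracks this change, so the step is expected to be modest, with no settled direction beyond the scatter. Compound 3 is expected at 400 nM, within 100 nM to 3000 nM. The expected step is a 2.0-fold higher number from compound 1 to compound 3 (0.30 log units; within the scatter).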

Compound 3, half-maximal inhibitory concentration: 220 nM
Compound 3: middle estimate off by 1.8-fold (0.26 log units), on the high side, and the stated range covers the measured number.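

In this assay, the step from butoxy to 4-aminophenyl on a carbonyl carbon reads a 1.1-fold higher number from compound 1 to compound 3 (0.04 log units; within the scatter) and so shows that this place accepts an aromatic ring and a hydrogen-bond donor in place of an open chain with no loss beyond the scatter. The oxygen-linked butoxy is therefore not needed here for this read-out in this pair. No measured property on hand accounts for this match. Open, from the compounds shown here alone, is whether a carboxylic acid in place of the amine on the 4-aminophenyl ring holds this level. Going by these compounds, a longer chain in place of butoxy is equally open.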